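A Pyridyl Ether in Place of a Fluorophenyl Ether

A few compounds are considered here, and "the series" means these few. Any claim that something is new, unique, unknown or untested is made for them only; others in the source may bear on it.

Compound 1, `COC1=CC(=O)c2c(COc3ccc(N)cc3)c(C)n(C)c2C1=O`, gives 160 nM in a functional assay on MIA PaCa-2 cells (Homo sapiens) for cytotoxicity, read by MTT assay, with a stated time of 72 h; a higher number here means a weaker inhibitor, a lower number a stronger inhibitor.
Compound 2, `COC1=CC(=O)c2c(COc3ccc(C#N)cc3)c(C)n(C)c2C1=O`, gives 192 nM.
Compound 3, `COC1=CC(=O)c2c(COc3ccc(F)cc3)c(C)n(C)c2C1=O`, gives 493 nM.

Compound 3 holds the highest number of the three; the nearest step to it is a 2.6-fold higher number from compound 2 to compound 3 (0.41 log units; beyond the scatter) and the furthest is a 3.1-fold higher number from compound 1 to compound 3 (0.49 log units; beyond the scatter). Compound 4, `COC1=CC(=O)c2c(COc3cccnc3)c(C)n(C)c2C1=O`, differs from compound 3 in one place: pyridin-3-yl in place of 4-fluorophenyl on an oxygen on a saturated carbon. Among the measured compounds shown here, none of the measured steps exchanges the ring itself; each only varies the group on the carbon-only ring, as in a 1.2-fold higher number from compound 1 to compound 2 (0.08 log units; within the scatter) and a 3.1-fold higher number from compound 1 to compound 3 (0.49 log units; beyond the scatter). For the measured compounds named here, the change to compound 4 therefore has no direct precedent, and in this assay the expected step is a 1.6-fold lower number from compound 3 to compound 4 (0.22 log units; within the scatter), modest and within the scatter. For compound 4 the expected value is 300 nM, between 90 nM and 1000 nM.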

Compound 4, half-maximal inhibitory concentration: 1820 nM
Compound 4: the middle estimate sits 6.1-fold (0.78 log units) below what was measured, and the stated range ends below it.
By their numbers in this assay, from the lowest: compounds 1 and 2 (each within the scatter of the next); then compound 3; then compound 4.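

Swapping the carbon-only ring for pyridin-3-yl on this oxygen weakens the compound in this assay against all three phenyl ethers: a 3.7-fold higher number from compound 3 to compound 4 (0.57 log units; beyond the scatter), a 9.5-fold higher number from compound 2 to compound 4 (0.98 log units; beyond the scatter) and an 11-fold higher number from compound 1 to compound 4 (1.06 log units; beyond the scatter). So at this position the ring itself matters, not only the group it carries. Nothing available here explains the loss.

Compound 4 differs from the others in two ways, with a ring nitrogen gained and a ring substituent lost, and these remain unseparated. An unsubstituted phenyl ether, or a pyridin-3-yl ring carrying an amino group, would tell them apart.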